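The compounds below may be only part of what the source reports. "The series", "measured", "known", "first", "only" and "open" are said of these compounds alone.

Compound 1 `COc1cc2c(Oc3ccc(NC(=O)c4nn(-c5cccc(F)c5)c(=O)cc4C)cc3F)ccnc2cc1OCCCN1CCCCC1`, compound 2 `COc1cc2c(Oc3ccc(NC(=O)c4nn(-c5cccc(F)c5)c(=O)cc4C)cc3F)ccnc2cc1OCCCN1CCC(C)CC1` and compound 3 `COc1cc2c(Oc3ccc(NC(=O)c4nn(-c5ccc(Cl)cc5Cl)c(=O)cc4C)cc3F)ccnc2cc1OCCCN1CCCCC1` share one core and differ at only two places. In a functional assay on NCI-H460 cells (Homo sapiens) for inhibition, read by MTT assay, with a stated time of 72 h (a lower number here means a stronger inhibitor, a higher number a weaker inhibitor), compound 1 gives 360 nM, compound 2 gives 250 nM and compound 3 gives 390 nM. Compound 2 differs from compound 1 by methyl in place of hydrogen on a saturated ring carbon, and this change made a 1.4-fold lower number from compound 1 to compound 2 (0.16 log units; within the scatter). Compound 3 differs from compound 1 by 2,4-dichlorophenyl in place of 3-fluorophenyl on an aromatic nitrogen, and that change made a 1.1-fold higher number from compound 1 to compound 3 (0.03 log units; within the scatter). So far, all three numbers sit within the scatter of one another, and no order among them can be drawn.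

Compound 4 `COc1cc2c(Oc3ccc(NC(=O)c4nn(-c5ccc(Cl)cc5Cl)c(=O)cc4C)cc3F)ccnc2cc1OCCCN1CCC(C)CC1` has not yet been measured in this assay. It differs from compound 3 by methyl in place of hydrogen on a saturated ring carbon, which is the same change that turns compound 1 into compound 2, made here on the core of compound 3. Because the earlier step of a 1.4-fold lower number from compound 1 to compound 2 (0.16 log units; within the scatter) stayed within the scatter, a step of about the same small size is expected here, a 1.4-fold lower number from compound 3 to compound 4 (0.14 log units; within the scatter). Compound 4 is therefore estimated to give 280 nM in this assay, with a likely range from 140 nM to 560 nM.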

Compound 4, half-maximal inhibitory concentration: 250 nM
Compound 4: middle estimate off by 1.1-fold (0.05 log units), on the high side; the measured number falls inside the stated range.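

In this assay, the methyl change that turns piperidin-1-yl into 4-methylpiperidin-1-yl gives a 1.6-fold lower number from compound 3 to compound 4 (0.19 log units; within the scatter) and reads the same on both cores: the same change on two cores in this assay, a 1.4-fold lower number (0.16 log units; within the scatter) from compound 1 to compound 2 and a 1.6-fold lower number (0.19 log units; within the scatter) from compound 3 to compound 4, 1.1-fold (0.03 log units) apart, within the scatter of two such steps. Replacing 3-fluorophenyl with 2,4-dichlorophenyl gives no change at the digits printed from compound 2 to compound 4 (within the scatter) and also reads the same on both cores: the same change on two cores in this assay, a 1.1-fold higher number (0.03 log units; within the scatter) from compound 1 to compound 3 and no change at the digits printed (within the scatter) from compound 2 to compound 4, 1.1-fold (0.03 log units) apart, within the scatter of two such steps. This shows that, for these four compounds, neither change moves the number beyond ordinary measurement noise on either core, but it does not show that either change truly strengthens or weakens inhibition, and small steps that agree are weak proof that an effect transfers from one core to another.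

Going by these compounds, it remains open whether a change that produces a step beyond the scatter would also carry over between these cores. A morpholin-4-yl group in place of piperidin-1-yl, or a phenyl group in place of the methyl, could test this, as could a nitrile on the aromatic ring that carries the halogens.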